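From compound 3 to compound 4: losing piperidin-1-yl

A few compounds are considered here, and "the series" means these few. Any claim that something is new, unique, unknown or untested is made for them only; others in the source may bear on it.

In a functional assay on ECa-109 cells (Homo sapiens) for antiproliferative activity, with a stated time of 72 h (on this read-out lower numbers stand for stronger inhibition and higher numbers for weaker inhibition), compound 3 (`COc1cc(OC)c(C(=O)/C=C/c2ccccc2Cl)c(O)c1CN1CCCCC1`) is lowest at 2500 nM, while compound 2 (`COc1cc(OC)c(C(=O)/C=C/c2ccccc2Cl)c(O)c1CN1CCCC1`) gives 6900 nM and compound 1 (`COC(=O)CN(C)Cc1c(OC)cc(OC)c(C(=O)/C=C/c2ccccc2Cl)c1O`) gives 13900 nM. The change to compound 4 (`COc1cc(OC)c(C(=O)/C=C/c2ccccc2Cl)c(O)c1CN(C)CC(=O)O`) is (carboxymethyl)(methyl)amino in place of piperidin-1-yl on a saturated chain carbon bound to an aromatic carbon. The nearest measured group is the ((methoxycarbonyl)methyl)(methyl)amino of compound 1. The most relevant measured change is its replacement by piperidin-1-yl, which gave a 5.6-fold lower number from compound 1 to compound 3 (0.75 log units; beyond the scatter). The ring change gave a smaller move, a 2.8-fold lower number from compound 2 to compound 3 (0.44 log units; beyond the scatter). For the measured compounds named here, no measured compound carries the free carboxymethyl group, so the reverse move is only an approximate guide. A move to a higher number is expected, estimated as a 5.6-fold higher number from compound 3 to compound 4 (0.75 log units; beyond the scatter). For compound 4 the estimated value is 14000 nM, with an expected range of 4000 nM to 50000 nM.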

Compound 4, half-maximal inhibitory concentration: 44400 nM
The estimate for compound 4 lay 3.2-fold (0.50 log units) below the measured number, and the stated range covers the measured number.
By their numbers in this assay, from the lowest: compound 3; then compounds 2 and 1 (each within the scatter of the next); then compound 4.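

In this assay the (carboxymethyl)(methyl)amino group gives the highest number of the series, with an 18-fold higher number from compound 3 to compound 4 (1.25 log units; beyond the scatter) as its largest step and a 6.4-fold higher number from compound 2 to compound 4 (0.81 log units; beyond the scatter) as the smaller step from the five-membered ring. The ester itself is not the limit at this place: hydrogen in place of methyl on an oxygen next to a carbonyl group gives a 3.2-fold higher number from compound 1 to compound 4 (0.50 log units; beyond the scatter) and so separates the acid from the ester beyond the scatter.

As far as these compounds go, whether an amide at that carbonyl or a longer chain before the carboxylic acid would sit nearer compound 1 or compound 4 stays open. Nothing at hand explains these steps.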